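The source may report more compounds than this note shows. Statements on the series, on what has been measured and on what is new or still open speak of the compounds shown alone.

- compound 1 (`CC(=O)N1CC(CC(=O)NO)(NS(=O)(=O)c2ccc(OCc3cc(C)nc4ccccc34)cc2)C1`): 800000 nM
- compound 2 (`CC(=O)N1CC(CC(=O)NO)(NS(=O)(=O)c2ccc(SCc3cc(C)nc4ccccc34)cc2)C1`): 1000000 nM
- compound 3 (`CC(=O)N1CC(CC(=O)NO)(NS(=O)(=O)c2ccc(Cc3cc(C)nc4ccccc34)cc2)C1`): 1900000 nM

In a physicochemical assay for solubility, with a stated time of 24 h, tested at 30 mg/mL (on this read-out lower numbers stand for lower solubility and higher numbers for higher solubility), compound 1 gives 800000 nM and lies within the scatter of compound 2, and only compound 3 stands apart from it, higher and beyond the scatter. Compound 4 (`CC(=O)N1CC(CC(=O)NO)(NS(=O)(=O)c2ccc(OCc3cc(C)nc4ccccc34)cc2C)C1`) keeps the core of compound 1 with a single change (methyl in place of hydrogen on an aromatic carbon), methyl in place of hydrogen on an aromatic carbon. Within the data shown here, no measured pair shows this change, so any forecast in this assay rests on judgement alone. A small downward move is expected, and none beyond the scatter is the likeliest reading. The estimated step (a 1.3-fold lower number from compound 1 to compound 4 (0.12 log units; within the scatter)) is accordingly modest. Compound 4 is expected at 600000 nM (estimated range 250000 nM to 1200000 nM).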

Compound 4, solubility: 900000 nM
The estimate for compound 4 lay 1.5-fold (0.18 log units) below the measured number, within the range that was stated.
By their numbers in this assay, from the lowest: compounds 1, 4, 2 and 3 (each within the scatter of the next, the first and the last beyond it).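

Methyl in place of hydrogen on an aromatic carbon, ortho to a large group and meta to a large group, gives a 1.1-fold higher number from compound 1 to compound 4 (0.05 log units; within the scatter) in this assay and is the first single-place step these compounds offer. At this position, then, one added methyl leaves the read-out within the scatter. No evidence on hand bears on this result. On these data alone, whether trifluoromethyl, methoxy or an amine at the same place would also stay within the scatter remains open, as does whether the same methyl would do so on the core of compound 3.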